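Swapping ethyl for bromo on a tetrazole core

The source may hold more compounds than are shown below. What is called first, only, known or untested is meant among the compounds shown, and "the series" means these compounds.

Measured compounds:
- compound 1 `Fc1ccc2ncc(-c3nn[nH]n3)cc2c1`, in a functional assay on the whole organism (strain Sprague-Dawley) for inhibition, with Rattus norvegicus as the target (a higher number here means that more compound is needed for the effect, a lower number that less compound is needed), gives only a limit, < 25 mg/kg
- compound 2 `O=C(O)c1cnc2cc(C(F)(F)F)ccc2c1`, in this assay gives only a limit, > 25 mg/kg
- compound 3 `CCc1cccc2c(=O)c(-c3nn[nH]n3)c[nH]c12`, in this assay gives 0.312 mg/kg

Compound 3 is the only one of the three with an actual number in this assay; the other two values are limits and not numbers, as the lines the limit of < 25 mg/kg in this assay, at which 1 of the 3 values shown sits, and the limit of > 25 mg/kg in this assay, at which 1 of the 3 values shown sits, show. Nothing here allows any step between measured compounds to be sized, so compound 3 stands alone as the reference point.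

Compound 4 `O=c1c(-c2nn[nH]n2)c[nH]c2c(Br)cccc12` has not yet been measured in this assay. It differs from compound 3 in one place: bromo in place of ethyl on an aromatic carbon. The group that leaves and the group that enters are both small, and each sits on the same aromatic carbon of the same ring.

Among the compounds with values here, no measured step of this kind is available, so the expectation is that the step of a 1.3-fold higher number from compound 3 to compound 4 (0.11 log units; within the scatter) stays within the usual scatter, in no clear direction. Compound 4 is therefore estimated at 0.4 mg/kg, in the range 0.1 mg/kg to 1.5 mg/kg.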

Compound 4, minimum effective dose: > 5 mg/kg
Compound 4: a limit, no number; the forecaster's own chance of this, stated with the estimate: 10%; middle value at least 12-fold (1.09 log units) from the limit.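

For compound 4 the read-out is a limit and not a number: the limit of > 5 mg/kg in this assay, at which 1 of the 4 values shown sits. Even so, in this assay bromo in place of ethyl on this aromatic carbon is a large change, with an at least 16-fold higher number from compound 3 to compound 4 (1.20 log units; beyond the scatter), so two small groups without hydrogen-bond donors or acceptors are not interchangeable at this position of the shared core. Compound 1 and compound 2 could not show this: both give only limits, and neither forms a one-place step with another compound here.

The compounds shown leave open whether ethyl is unusual at this carbon or whether methyl, a longer chain such as propyl, or an amine would also work at a low dose. They also leave open the true size of this step and whether the same swap would have a similar effect on another carbon of the ring.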